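Shortening an alkyl chain: what to expect of compound 4

This account rests on a few compounds, and the source may have more. Where it says the series, first, only, none or still open, it means among the compounds named here.

Measured compounds in a functional assay (spleen, spleen) for activation, with Mus musculus as the target; on this read-out lower numbers stand for an effect already at smaller amounts and higher numbers for an effect only at larger amounts of compound:
compound 1, `CCSc1nc(N)c2nc(O)n(Cc3ccccc3)c2n1`, gives 0.1 uM
compound 2, `CCCSc1nc(N)c2nc(O)n(Cc3ccccc3)c2n1`, gives 0.01 uM
compound 3, `CCCCCNc1nc(N)c2nc(O)n(Cc3ccccc3)c2n1`, gives 0.1 uM

Compound 1 arises from compound 2 by the change (hydrogen in place of methyl on a saturated chain carbon, two bonds along the chain from a sulfur), and that change made the step of a 10-fold higher number from compound 2 to compound 1 (1.00 log units; beyond the scatter). Compound 3 differs from compound 2 in the core substituent, (pentylamino in place of propylsulfanyl on an aromatic carbon), with the step of a 10-fold higher number from compound 2 to compound 3 (1.00 log units; beyond the scatter), while the comparison no change at the digits printed from compound 1 to compound 3 (within the scatter) shows compound 3 and compound 1 side by side.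

Compound 4, `CCCCNc1nc(N)c2nc(O)n(Cc3ccccc3)c2n1`, is related to compound 3 by hydrogen in place of methyl on a saturated chain carbon, four bonds along the chain from a nitrogen on an aromatic ring. This is the same kind of change as that from compound 2 to compound 1, not the same: there it sat two bonds along the chain from a sulfur, here it sits four bonds along the chain from a nitrogen on an aromatic ring, and the two cores differ as described above.

Since the earlier shortening gave a 10-fold higher number from compound 2 to compound 1 (1.00 log units; beyond the scatter), compound 4 is expected to show a step of a 3.0-fold higher number from compound 3 to compound 4 (0.48 log units; beyond the scatter), somewhat smaller because the chain on compound 3 is longer and its value is 0.1 uM. The value of compound 4 is therefore estimated at 0.3 uM, between 0.1 uM and 1 uM.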

Compound 4, minimum effective concentration: 1 uM
Beside the measured number, compound 4's estimate is 3.3-fold (0.52 log units) below it, within the range that was stated.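

In this assay, replacing the chain-end methyl with hydrogen on the pentylamino compound gave a 10-fold higher number from compound 3 to compound 4 (1.00 log units; beyond the scatter), and this step matches the one seen on the sulfur-linked pair: the same change on two cores in this assay, a 10-fold higher number (1.00 log units; beyond the scatter) from compound 2 to compound 1 and a 10-fold higher number (1.00 log units; beyond the scatter) from compound 3 to compound 4, 1.0-fold (0.00 log units) apart, within the scatter of two such steps

Exchanging the sulfur-linked chains for butylamino gave a 100-fold higher number from compound 2 to compound 4 (2.00 log units; beyond the scatter) and a 10-fold higher number from compound 1 to compound 4 (1.00 log units; beyond the scatter), leaving compound 4 with the highest number of the four. The shortening therefore carried over in this one comparison, but a single pair of steps does not show that it would hold at other chain lengths or on other cores.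

The compounds shown leave open how a propylamino or hexylamino chain would fit this trend, and whether a longer sulfur-linked chain, such as butylsulfanyl, would continue the fall in the number seen from compound 1 to compound 2. They also leave open whether the step would persist with a carboxylic acid at the chain end or with a group other than benzyl on the shared core.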